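From compound 1 to compound 3: adding a chain

The source may hold more compounds than are shown below. What is called first, only, known or untested is meant among the compounds shown, and "the series" means these compounds.

Measured in a functional assay on A549 cells (Homo sapiens) for inhibition, read by MTT assay, with a stated time of 72 h; on this read-out higher numbers stand for weaker inhibition of growth and lower numbers for stronger inhibition of growth:
Compound 1 `CC(C)=CC(=O)NC(=N)N`: > 100000 nM (a limit)
Compound 2 `C=C1CCCC(C)(C)[C@@H]1CC/C(C)=C/C(=O)NC(=N)NC(=O)C=C(C)C`: 29400 nM

Compound 1 has no number, only (the limit of > 100000 nM in this assay, at which 1 of the 2 values shown sits). On these data alone, how far it lies from any other compound therefore remains open. Compound 2 does give a number, 29400 nM.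

Compound 3 `CC(C)=CCC/C(C)=C/C(=O)NC(=N)N` is built from compound 1 by one change: 3-methylbut-2-en-1-yl in place of hydrogen on a saturated chain carbon bound to a double-bonded chain carbon. A 3-methylbut-2-en-1-yl group takes the place of hydrogen on a saturated chain carbon bound to a double-bonded chain carbon.

With compound 2 at 29400 nM as the only numbered reference, a modest step towards stronger inhibition is expected in this assay. The result for compound 3 may stay at the limit. The estimated change is an at least 1.6-fold lower number from compound 1 to compound 3 (0.22 log units; that floor lies within the scatter). For compound 3 the expected value is 60000 nM, with an estimated range from 25000 nM to 150000 nM.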

Compound 3, concentration for 50% growth inhibition: 76500 nM
Beside the measured number, compound 3's estimate is 1.3-fold (0.11 log units) below it, within the range that was stated.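

With the 3-methylbut-2-en-1-yl group on a saturated chain carbon bound to a double-bonded chain carbon, compound 3 gives 76500 nM in this assay and so provides a number rather than a limit for this small chain-bearing structure. The step reads as an at least 1.3-fold lower number from compound 1 to compound 3 (0.11 log units; that floor lies within the scatter) and gives only a floor, so the true size of the change remains unfixed. Compound 1 remains a limit and not a number: the limit of > 100000 nM in this assay, at which 1 of the 3 values shown sits.

The compounds shown leave open how far compound 1 really lies from compound 3. They also leave open how a saturated chain of the same length, a longer chain or an amine on that saturated chain carbon would compare with the 3-methylbut-2-en-1-yl group.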